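A cyclohexyl group in place of 4-methylphenyl

The compounds below may be only part of what the source reports. "The series", "measured", "known", "first", "only" and "open" are said of these compounds alone.

Compound 3 `Cc1ccc(N2CCN(C(=S)SCc3ccc(C(=O)Nc4ccccc4N)cc3)CC2)cc1` stands lowest of the three numbers in a functional assay on MGC-803 cells (Homo sapiens) for antiproliferative activity, read by CCK-8 assay, with a stated time of 72 h, tested at 8 uM (a higher number here means a stronger effect of the compound at the concentration tested, a lower number a weaker effect), where compound 3 gives 19.8%. Compound 1 `COc1ccc(N2CCN(C(=S)SCc3ccc(C(=O)Nc4ccccc4N)cc3)CC2)cc1` gives 22.9% in this assay, a value within the scatter of compound 3 (a number 3.1 percentage points lower from compound 1 to compound 3 (within the scatter)), while compound 2 `N#Cc1ccc(N2CCN(C(=S)SCc3ccc(C(=O)Nc4ccccc4N)cc3)CC2)cc1` gives 37.6%, so that a number 17.8 percentage points lower from compound 2 to compound 3 (beyond the scatter) and a number 14.7 percentage points higher from compound 1 to compound 2 (beyond the scatter). Compound 4 `Nc1ccccc1NC(=O)c1ccc(CSC(=S)N2CCN(C3CCCCC3)CC2)cc1` differs from compound 3 by cyclohexyl in place of 4-methylphenyl on an amine nitrogen in a ring. Among the compounds with values here, no measured step exchanges the aromatic ring itself; the three steps only vary the group on it, two of them modest and one within the scatter. The expectation for compound 4 therefore rests on little, and the step of a number 4.2 percentage points higher from compound 3 to compound 4 (within the scatter) is estimated to stay small. Compound 4 is expected to give 24%, between 10% and 42%.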

Compound 4, a percentage reported as inhibition, at one concentration (the size of the read-out at that concentration, not a potency): 75.3%
For compound 4 the middle estimate is 51.3 percentage points below the measured one; the measured number lies above the stated range.
By their numbers in this assay, from the lowest: compounds 3 and 1 (each within the scatter of the next); then compound 2; then compound 4.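

In this assay, replacing the aromatic ring on this amine nitrogen with cyclohexyl gives large steps from all three aryl compounds: a number 55.5 percentage points higher from compound 3 to compound 4 (beyond the scatter), a number 52.4 percentage points higher from compound 1 to compound 4 (beyond the scatter) and a number 37.7 percentage points higher from compound 2 to compound 4 (beyond the scatter). The substituent changes on the aromatic ring gave modest steps at most, so the identity of the ring at this position matters more here than the group it carries. Nothing available explains this gain. From the compounds shown here alone, it remains open whether a cyclopentyl ring, an open-chain hexyl group or a piperidine ring would keep it, and a single-concentration read-out gives no potency for compound 4.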